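The source may hold more compounds than are shown below. What is called first, only, known or untested is meant among the compounds shown, and "the series" means these compounds.

Measured compounds:
compound 1 `COc1cc(Oc2cccc(Nc3ccccc3)c2)cc(OC)c1CN[C@H](C)c1ccccc1`: > 20000 nM
compound 2 `COc1ccc([C@@H](C)NCc2c(OC)cc(Oc3cccc(Nc4ccccc4)c3)c(OC)c2OC)cc1`: 2440 nM

Compound 1 `COc1cc(Oc2cccc(Nc3ccccc3)c2)cc(OC)c1CN[C@H](C)c1ccccc1` and compound 2 `COc1ccc([C@@H](C)NCc2c(OC)cc(Oc3cccc(Nc4ccccc4)c3)c(OC)c2OC)cc1` were tested in a functional assay on HCT-116 cells (Homo sapiens) for inhibition, read by MTT assay, with a stated time of 72 h; a higher number here means a weaker inhibitor, a lower number a stronger inhibitor. Compound 1 gives > 20000 nM, which is a limit of the assay and not a number. Compound 2 gives 2440 nM. Going by the values given here, the two differ in more than one place, so no single step between them can be read off. What is known of compound 1 is therefore only (the limit of > 20000 nM in this assay, at which 1 of the 2 values shown sits).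

Compound 3 `COc1cc(Oc2cccc(Nc3ccccc3)c2)cc(OC)c1CNCc1ccc(O)cc1` differs from compound 1 in one place: 4-hydroxybenzyl in place of 1-phenylethyl on an amine nitrogen. Since compound 1 stands only at a limit, the size of this step cannot be anchored on a measured number. It is expected to run toward stronger inhibition, an at least 1.6-fold lower number from compound 1 to compound 3 (0.22 log units; that floor lies within the scatter), though it may stay within the scatter. Compound 3 is estimated at 12000 nM in this assay, between 3000 nM and 40000 nM, with a real chance that only a limit is again reported.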

Compound 3, half-maximal inhibitory concentration: 3360 nM
Compound 3: middle estimate off by 3.6-fold (0.55 log units), on the high side; the measured number falls inside the stated range.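

In this assay, the substituent on the amine nitrogen proves able to move the result: 4-hydroxybenzyl in place of 1-phenylethyl gives an at least 5.9-fold lower number from compound 1 to compound 3 (0.77 log units; beyond the scatter). Compound 1 gives > 20000 nM, which is a limit of the assay and not a number, so the step has a floor and no fixed size: the limit of > 20000 nM in this assay, at which 1 of the 3 values shown sits. The stereocentre of 1-phenylethyl leaves and the hydrogen-bond donor of 4-hydroxybenzyl enters in this same step, so the two changes cannot be told apart.

Which of them carries the step remains open. So does what a plain benzyl or a 4-methoxybenzyl would give on this amine nitrogen, and whether a hydroxyl group on the ring of 1-phenylethyl would give a step of similar size.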